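Replacing difluoromethyl with methylamino

The compounds below may be only part of what the source reports. "The series", "measured", "known", "first", "only" and "open" are said of these compounds alone.

In a physicochemical assay for lipophilicity (a higher number here means a more lipophilic compound, a lower number a more polar compound), compound 3 (`C[C@H](NC(=O)c1cc(C(F)(F)F)nn1C)c1nc(-c2ccnc(C(F)F)c2)no1`) gives 3.4 and stands level with compound 1 (`Cc1cc(-c2noc([C@H](C)NC(=O)c3cc(C(F)(F)F)nn3C)n2)ccn1`) at 3.3 and well under compound 2 (`COc1cc(-c2noc([C@H](C)NC(=O)c3cc(C(F)(F)F)nn3C)n2)cc(C)n1`) at 4.4 on the same scale. Compound 4 (`CNc1cc(-c2noc([C@H](C)NC(=O)c3cc(C(F)(F)F)nn3C)n2)ccn1`) has methylamino in place of difluoromethyl on an aromatic carbon. Going by the values given here, no measured step involves methylamino. Difluoromethyl in place of methyl gave a number 0.10 log units higher from compound 1 to compound 3 (within the scatter) and offers only a weak guide. Two other steps, a number 1.10 log units higher from compound 1 to compound 2 (beyond the scatter) and a number 1.00 log units lower from compound 2 to compound 3 (beyond the scatter), show that a change of substituent can carry the number beyond the scatter. Going by the exchanged groups alone, a modest fall is expected, with a number 0.60 log units lower from compound 3 to compound 4 (beyond the scatter) as the estimated step. The estimated value for compound 4 is 2.8 within a range of 2.3 to 3.3 overall.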

Compound 4, distribution coefficient: 3.4
Beside the measured number, compound 4's estimate is 0.60 log units below it; the whole stated range lies below it.
By their numbers in this assay, from the lowest: compounds 1, 3 and 4 (each within the scatter of the next); then compound 2.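

In this assay the step to methylamino in place of difluoromethyl gives no change at the digits printed from compound 3 to compound 4 (within the scatter) and so leaves the number level, although methylamino brings a hydrogen-bond donor and acceptor that difluoromethyl lacks. Methylamino in place of methyl likewise gives a number 0.10 log units higher from compound 1 to compound 4 (within the scatter) at the same place, so all three groups there stay level with each other. Only 2-methoxy-6-methylpyridin-4-yl stands apart, with a number 1.00 log units lower from compound 2 to compound 4 (beyond the scatter) in the same assay. Whether a dimethylamino group or a carboxylic acid at this place would also stay level remains open, and nothing given here explains the level result.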